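The source may hold more compounds than are shown below. What is called first, only, known or untested is meant among the compounds shown, and "the series" means these compounds.

Of the compounds shown here, three have been measured in an assay on HEK293 cells for displacement of a labelled ligand from B1 bradykinin receptor (Homo sapiens), read by scintillation counting; on this read-out higher numbers stand for weaker inhibition and lower numbers for stronger inhibition. Compound 1 `CCN(CC)CCN1CCN(C(=O)COCCN(C)S(=O)(=O)c2c(C)cc(OC)cc2C)CC1` gives 10 nM, compound 2 `COc1cc(C)c(S(=O)(=O)N(C)CCOCC(=O)N2CCN(CCCN(C)C)CC2)c(C)c1` gives 5.8 nM, and compound 3 `CN(Cc1ccc(C2=NCCN2)cc1)C(=O)COCCN(C)S(=O)(=O)c1ccccc1C(F)(F)F` gives 2.8 nM. Compound 2 thus holds the second highest of the three numbers; its value and that of compound 1 lie within the scatter of each other, while the gap to compound 3 lies beyond the scatter, with compound 3 giving the lower number. For the measured compounds named here, the only single-point step among the measured compounds is a 1.7-fold lower number from compound 1 to compound 2 (0.24 log units; within the scatter). Compound 4 `CCN1CCC(N2CCN(C(=O)COCCN(C)S(=O)(=O)c3c(C)cc(OC)cc3C)CC2)CC1` is yet to be measured. It differs from compound 2 at the same amine nitrogen in a ring: 1-ethylpiperidin-4-yl in place of 3-(dimethylamino)propyl on an amine nitrogen in a ring. Going by the values given here, the one step that bears on this change, from compound 1 to compound 2, stayed within the scatter, so a further exchange of the group on that nitrogen is expected to move this assay little, if at all. Among the compounds with values here, no measured step tests a ring in place of a chain at that position, so the range must stay wide. Compound 4 is therefore estimated at 6 nM, within 2 nM to 20 nM. The expected step is a 1.0-fold higher number from compound 2 to compound 4 (0.01 log units; within the scatter).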

Compound 4, inhibition constant: 0.2 nM
Beside the measured number, compound 4's estimate is 30-fold (1.48 log units) above it; the whole stated range lies above it.
By their numbers in this assay, from the lowest: compound 4; then compound 3; then compounds 2 and 1 (each within the scatter of the next).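

In this assay, the group on this amine nitrogen in a ring matters far more than the two open chains suggested: 1-ethylpiperidin-4-yl in place of 3-(dimethylamino)propyl gives a large change (a 29-fold lower number from compound 2 to compound 4 (1.46 log units; beyond the scatter)), and in place of 2-(diethylamino)ethyl it gives another (a 50-fold lower number from compound 1 to compound 4 (1.70 log units; beyond the scatter)). The two chains stayed within the scatter of each other, so among these compounds it is the one with the ring that stands apart. Nothing available here explains this change.

With only one ring example, the compounds shown cannot separate the effect of the ring from that of the ethyl group on its nitrogen. A 1-methylpiperidin-4-yl or a 1-ethylpyrrolidin-3-yl group at the same place would show how much of the ring's shape and substitution this result depends on.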